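A few compounds are considered here, and "the series" means these few. Any claim that something is new, unique, unknown or untested is made for them only; others in the source may bear on it.

The measured compounds:

Compound 1, `CN(C)C(=O)c1cc2cnc(Nc3ccc(S(=O)(=O)NCCCCN=C=S)cc3)nc2n1C1CCCC1`, gives 72.7% in a functional assay on NCI-H1299 cells (Homo sapiens) for inhibition, read by CCK-8 assay, with a stated time of 72 h, tested at 10 uM; a lower number here means a weaker effect, a higher number a stronger effect of the compound at the concentration tested.
Compound 2, `CN(C)C(=O)c1cc2cnc(Nc3ccc(S(=O)(=O)NCCCCCN=C=S)cc3)nc2n1C1CCCC1`, gives 83.4%.
Compound 3, `CN(C)C(=O)c1cc2cnc(Nc3ccc(C(=O)NCCCCCN=C=S)cc3F)nc2n1C1CCCC1`, gives 86.7%.

The change from compound 1 to compound 2 is a group of 4 heavy atoms (2 carbon, 1 nitrogen, 1 sulfur; no ring) in place of a group of 3 heavy atoms (1 carbon, 1 nitrogen, 1 sulfur; no ring), on a saturated chain carbon, four bonds along the chain from a sulfonamide nitrogen, and it made a number 10.7 percentage points higher from compound 1 to compound 2 (beyond the scatter). Compound 3 carries a different core from compound 1; the difference between the two cores is not broken down here. Its value lies within the scatter of that of compound 2, while the value of compound 1 sits beyond the scatter from it.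

Compound 4, `CN(C)C(=O)c1cc2cnc(Nc3ccc(C(=O)NCCCCCCN=C=S)cc3F)nc2n1C1CCCC1`, has not yet been measured. It differs from compound 3 by a group of 4 heavy atoms (2 carbon, 1 nitrogen, 1 sulfur; no ring) in place of a group of 3 heavy atoms (1 carbon, 1 nitrogen, 1 sulfur; no ring), on a saturated chain carbon, five bonds along the chain from an amide-type nitrogen. This is the same kind of change as that from compound 1 to compound 2, though the place is not the same: there the group sat four bonds along the chain from a sulfonamide nitrogen, here it sits five bonds along the chain from an amide-type nitrogen. The expectation for compound 4 rests on a number 10.7 percentage points higher from compound 1 to compound 2 (beyond the scatter), tempered by the fact that compound 3 already gives 86.7%, leaving little room upward in a percentage read-out. The estimated step is therefore a number 3.3 percentage points higher from compound 3 to compound 4 (within the scatter), smaller than the earlier one. Compound 4 is expected to give about 90%, with a likely range from 80% to 97%.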

Compound 4, a percentage reported as inhibition, at one concentration (the size of the read-out at that concentration, not a potency): 77.6%
Beside the measured number, compound 4's estimate is 12.4 percentage points above it, and the stated range ends above it.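

In this assay, the same change that raised the read-out on the core of compound 1 gave a number 9.1 percentage points lower from compound 3 to compound 4 (within the scatter), so the gain did not carry over to the core of compound 3. The two steps differ when set side by side: the same change on two cores in this assay, a number 10.7 percentage points higher (beyond the scatter) from compound 1 to compound 2 and a number 9.1 percentage points lower (within the scatter) from compound 3 to compound 4, 19.8 percentage points apart, beyond the scatter of two such steps. Among these compounds, this shows that the change cannot be counted on to have the same outcome on both cores, but it does not show what separates them: each core supplies only one pair, the change sits four bonds along the chain from a sulfonamide nitrogen in one and five bonds along the chain from an amide-type nitrogen in the other, and the difference between the cores is not broken down.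

The compounds shown leave open how a longer chain would behave on either core, and whether an amine at the chain end would do the same as the group present here. They also leave open how the compounds compare at other concentrations, as each value gives the size of the effect at a single concentration.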